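Replacing the (2-phenylethenyl)carbonyl Group of Compound 1

A few compounds are considered here, and "the series" means these few. Any claim that something is new, unique, unknown or untested is made for them only; others in the source may bear on it.

Compound 1 `CCN(CC)c1ccc2cc(C(=O)c3ccc(N4CCN(C(=O)CN5CCN(C(=O)/C=C/c6ccccc6)CC5)CC4)cc3)oc2c1` was tested in a functional assay on HCT-116 cells (Homo sapiens) for cytotoxicity, read by MTT assay, with a stated time of 48 h (a lower number here means a stronger inhibitor, a higher number a weaker inhibitor), and gives 6810 nM. Compound 2 `CCN(CC)c1ccc2cc(C(=O)c3ccc(N4CCN(C(=O)CN5CCN(S(=O)(=O)c6ccc(C#N)cc6)CC5)CC4)cc3)oc2c1` carries a (4-cyanophenyl)sulfonyl group where compound 1 has the (2-phenylethenyl)carbonyl; in the same assay compound 2 gives 36400 nM. Among the measured compounds shown here, of these two numbers, compound 1 has the lower one, and the only measured step, a 5.3-fold higher number from compound 1 to compound 2 (0.73 log units; beyond the scatter), shows that exchanging the group on this ring nitrogen moved the number by a modest amount toward weaker inhibition.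

Compound 3 `CCN(CC)c1ccc2cc(C(=O)c3ccc(N4CCN(C(=O)CN5CCN(Cc6ccc(F)c(F)c6)CC5)CC4)cc3)oc2c1` changes the same position in a different way: 3,4-difluorobenzyl in place of (2-phenylethenyl)carbonyl on an amine nitrogen in a ring. For the measured compounds named here, no measured pair shows this particular exchange, so the step from compound 1 to compound 2 is the only guide, and it says that replacing this group has so far cost potency by a modest margin. A change of similar size, in the same direction, is therefore expected, although a result within the scatter would not be surprising. The step that this expectation means is a 1.8-fold higher number from compound 1 to compound 3 (0.25 log units; within the scatter). Compound 3 is estimated to give 12000 nM in this assay, with a range from 3000 nM to 40000 nM.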

Compound 3, half-maximal inhibitory concentration: 26300 nM
Compound 3: middle estimate off by 2.2-fold (0.34 log units), on the low side, and the stated range covers the measured number.
By their numbers in this assay, from the lowest: compound 1; then compounds 3 and 2 (each within the scatter of the next).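

A second, quite different replacement now points the same way: in this assay there is a 3.9-fold higher number from compound 1 to compound 3 (0.59 log units; beyond the scatter), so the number has risen with both a sulfonyl-linked and a benzyl group on this ring nitrogen. The two replacements cannot be told apart, with a 1.4-fold lower number from compound 2 to compound 3 (0.14 log units; within the scatter), although the 3,4-difluorobenzyl and the (4-cyanophenyl)sulfonyl differ in their atoms and in how they attach to the nitrogen. Among these three compounds, compound 1 alone stands apart with the lowest number, but no measurement accompanying these results accounts for the difference.

Still open, going by these compounds, is which part of the (2-phenylethenyl)carbonyl goes with the lower number: its carbonyl, its double bond outside the aromatic ring, or its aromatic ring. A benzoyl group, a 3-phenylpropanoyl group with its saturated chain, or a small acetyl group on the same ring nitrogen would separate these parts, each keeping the carbonyl while removing the double bond, the aromatic ring, or both.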